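Swapping the oxime ether tail for a cyclohexyl group

The source may hold more compounds than are shown below. What is called first, only, known or untested is meant among the compounds shown, and "the series" means these compounds.

Of the compounds shown here, three sharing one core have been measured in a physicochemical assay for lipophilicity, using the shake flask method; on this read-out lower numbers stand for lower lipophilicity and higher numbers for higher lipophilicity. Compound 1 `CCOC(=O)CO/N=C/c1c(N)ncnc1Oc1ccc(NC(=O)C2(C(=O)Nc3ccc(F)cc3)CC2)cc1F` gives 3.15, compound 2 `Nc1ncnc(Oc2ccc(NC(=O)C3(C(=O)Nc4ccc(F)cc4)CC3)cc2F)c1/C=N/OCC(=O)N1CCOCC1` gives 2.1, and compound 3 `CNc1ncnc(Oc2ccc(NC(=O)C3(C(=O)Nc4ccc(F)cc4)CC3)cc2F)c1/C=N/OC` gives 3.52. Compound 2 therefore stands lowest of the three, beyond the scatter from both others. Compound 4 `Nc1ncnc(Oc2ccc(NC(=O)C3(C(=O)Nc4ccc(F)cc4)CC3)cc2F)c1/C=N/OC1CCCCC1` is not yet measured; it differs from compound 2 by cyclohexyl in place of ((morpholin-4-yl)carbonyl)methyl on an oxygen. For the measured compounds named here, the one step that bears on this is a number 1.05 log units lower from compound 1 to compound 2 (beyond the scatter), which runs the opposite way, and compound 4 drops the whole morpholine-bearing group rather than merely swapping one piece of it. A large rise is therefore expected, estimated as a number 2.10 log units higher from compound 2 to compound 4 (beyond the scatter), giving compound 4 an expected value of 4.2 with a range from 3.6 to 4.8.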

Compound 4, partition coefficient: 4.69
Compound 4: middle estimate off by 0.49 log units, on the low side; low and high end bracket the measured number.
By their numbers in this assay, from the lowest: compound 2; then compound 1; then compound 3; then compound 4.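

The earlier step changed only the end of the tail, whereas here the whole group on the oxygen is replaced. In this assay, cyclohexyl in place of ((morpholin-4-yl)carbonyl)methyl gives a number 2.59 log units higher from compound 2 to compound 4 (beyond the scatter) and cyclohexyl in place of (ethoxycarbonyl)methyl gives a number 1.54 log units higher from compound 1 to compound 4 (beyond the scatter) so the number rises from both carbonyl-bearing tails. Nothing available explains these rises. Still open, going by these compounds, is where other groups on this oxygen would fall, such as a phenyl ring, a tail ending in a carboxylic acid, or one ending in an amine.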